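From Methylsulfanyl to Methylsulfonyl on the Shared Core

A few compounds are considered here, and "the series" means these few. Any claim that something is new, unique, unknown or untested is made for them only; others in the source may bear on it.

Of the compounds shown here, two have been measured in a functional assay on CHO cells for agonist activity at Alpha-2C adrenergic receptor (Homo sapiens); on this read-out lower numbers stand for smaller maximal responses and higher numbers for larger maximal responses. Compound 1 `CSc1ccc(C)cc1NCC1=NCCN1` gives 81%, and compound 2 `COc1ccc(SC)c(NCC2=NCCN2)c1` gives 74%. Compound 1 has the higher of the two numbers, but the step of a number 7 percentage points lower from compound 1 to compound 2 (within the scatter) is within the scatter, so the two compounds cannot be told apart on this read-out. Compound 3 `Cc1ccc(S(C)(=O)=O)c(NCC2=NCCN2)c1` has not yet been measured. It differs from compound 1 in one place: methylsulfonyl in place of methylsulfanyl on an aromatic carbon. Going by the values given here, no measured step changes the sulfur-bearing group, so nothing seen so far speaks directly to this change; the only measured step, from methyl to methoxy, stayed within the scatter. The estimate for compound 3 therefore leans on compound 1 alone and is held wide: a step of a number 11 percentage points lower from compound 1 to compound 3 (beyond the scatter) is expected, and compound 3 is estimated at 70%, somewhere between 45% and 90%.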

Compound 3, largest response reached (reported as maximum), in percent of the reference or control that the assay uses: 76%
Compound 3: the middle estimate sits 6 percentage points below what was measured; the range from low to high includes it.
By their numbers in this assay, from the lowest: compounds 2, 3 and 1 (each within the scatter of the next).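

At this position, ortho to a group of 7 heavy atoms and para to a methyl group, methylsulfonyl in place of methylsulfanyl gives a number 5 percentage points lower from compound 1 to compound 3 (within the scatter) in this assay. Going by these compounds alone, this is the first measured step that changes the sulfur-bearing group itself, and it shows that a group of 4 heavy atoms in place of one of 2 heavy atoms leaves the maximal response indistinguishable on this read-out. Nothing shown here explains why the two compounds cannot be told apart.

The compounds shown leave open whether another kind of group at this position, such as an amine or a carboxylic acid, would also stay within the scatter of compound 1. As far as these compounds go, it also remains open whether a plain hydrogen there, with no sulfur at all, would do the same.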